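The source may hold more compounds than are shown below. What is called first, only, known or untested is meant among the compounds shown, and "the series" means these compounds.

Measured so far:
compound 1 `COc1ccc(-c2c(S(=O)(=O)c3cccc(C#N)c3)cnc3cc(F)ccc23)cc1` — 0.92 mL/min
compound 2 `COc1cccc(-c2c(S(=O)(=O)c3cc(F)cc(F)c3)cnc3cc(F)ccc23)c1` — 1.81 mL/min

In an ADME assay on microsomes from liver (Homo sapiens) for metabolic stability, tested at 2.5 uM (a lower number here means slower removal, a higher number faster removal of the compound), compound 1 gives 0.92 mL/min and compound 2 gives 1.81 mL/min; the two numbers lie within the usual scatter of each other, so neither can be called higher or lower. Compound 3 `COc1cccc(-c2c(S(=O)(=O)c3cccc(C#N)c3)cnc3cc(F)ccc23)c1` has not yet been measured. It differs from compound 2 in one place: 3-cyanophenyl in place of 3,5-difluorophenyl on a sulfonyl sulfur. Going by the values given here, no measured pair shows this exchange, so the step in this assay is expected to be small, at most a modest drop, nothing clearly beyond the scatter: a 1.5-fold lower number from compound 2 to compound 3 (0.18 log units; within the scatter). The estimate is guided by compound 1, which carries the same 3-cyanophenyl and gives 0.92 mL/min. Compound 3 is expected at 1.2 mL/min, between 0.6 mL/min and 2.4 mL/min.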

Compound 3, intrinsic clearance in a liver preparation (reported as CLH), per the amount of preparation that the assay uses: 1.83 mL/min
Beside the measured number, compound 3's estimate is 1.5-fold (0.18 log units) below it; measured number inside the range.
By their numbers in this assay, from the lowest: compounds 1, 2 and 3 (each within the scatter of the next).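

In this assay, going by these compounds alone, 3-cyanophenyl in place of 3,5-difluorophenyl on a sulfonyl sulfur gives a 1.0-fold higher number from compound 2 to compound 3 (0.00 log units; within the scatter) and thus offers the first direct reading of this exchange, which leaves the two groups inseparable. 3-Methoxyphenyl in place of 4-methoxyphenyl on an aromatic carbon gives a 2.0-fold higher number from compound 1 to compound 3 (0.30 log units; within the scatter) and is likewise not separated from the scatter. Nothing at hand explains either result. The compounds shown leave open how an amine or a carboxylic acid on a sulfonyl sulfur, in place of these aromatic groups, would read in this assay.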